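The source may hold more compounds than are shown below. What is called first, only, known or untested is meant among the compounds shown, and "the series" means these compounds.

Compound 1 `O=CN(O)C(CCc1ncccn1)CS(=O)(=O)N1CCN(c2ccc(Cl)cn2)CC1`: in an ADME assay for inhibition of Bile salt export pump (Homo sapiens), read by scintillation counting, with a stated time of 5 min (a lower number here means a stronger inhibitor, a higher number a weaker inhibitor), compound 1 gives < 10000 nM, a limit of the assay rather than a number.
Compound 2 `O=CN(O)C(CCc1ccccc1)CS(=O)(=O)N1CCN(c2ccc(F)cc2)CC1`: in this assay compound 2 gives < 10000 nM, again a limit.
Compound 3 `O=CN(O)C(CCc1cccnc1)CS(=O)(=O)N1CCN(c2ccc(Cl)cn2)CC1`: in this assay compound 3 gives < 10000 nM, also a limit.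

Compound 3 therefore stands where all three measured values sit, at the limit (the limit of < 10000 nM in this assay, at which 3 of the 3 values shown sit), with no number of its own. Compound 4 `O=CN(O)C(CCc1ccccc1)CS(=O)(=O)N1CCN(c2ccc(Cl)cn2)CC1` differs from it in one place: phenyl in place of pyridin-3-yl on a saturated chain carbon, three bonds along the chain from an amide-type nitrogen. For the measured compounds named here, the only measured step that touches this position, a step that the two limits leave unreadable from compound 1 to compound 3, cannot be read. Compound 2, which carries the same phenethyl group on a different aryl piperazine, likewise shows only the limit, so no step beyond the scatter is expected. Compound 4 is estimated at 4000 nM, within 400 nM to 10000 nM. The expected step from compound 3 is a step that the limit leaves unreadable from compound 3 to compound 4, most likely reported again only as a limit.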

Compound 4, half-maximal inhibitory concentration: < 10000 nM
Compound 4: no number, only a limit; the forecaster's own chance of this, stated with the estimate: 75%; the middle value lies beyond the limit too.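

Compound 4 gives only a limit, so its steps from compound 1, compound 2 and compound 3 in this assay cannot be read: the limit of < 10000 nM in this assay, at which 4 of the 4 values shown sit. The compounds shown leave open how strongly each inhibits, and whether phenyl, pyridin-3-yl or pyrimidin-2-yl changes that.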